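Notes on compound 3, the methyl analogue of compound 2

This account rests on a few compounds, and the source may have more. Where it says the series, first, only, none or still open, it means among the compounds named here.

Measured so far in a physicochemical assay for lipophilicity, at pH 7.4; on this read-out lower numbers stand for lower lipophilicity and higher numbers for higher lipophilicity
Compound 1 `CCc1ccc(N(CC(C)C)S(=O)(=O)c2ccc3c(c2)C(O)CC(C2CCNCC2)O3)cc1` gives 1.04
Compound 2 `CCc1ccc(N(CC(C)C)S(=O)(=O)c2ccc3c(c2)C(O)CC(CC2CCOCC2)O3)cc1` gives 4.44

Within the data shown here, compound 2 holds the higher of these two numbers, and compound 1 is its only neighbour. Compound 3 `CCc1ccc(N(CC(C)C)S(=O)(=O)c2ccc3c(c2)C(O)CC(C(C)C2CCOCC2)O3)cc1` has yet to be measured. Its difference from compound 2 is methyl in place of hydrogen on a saturated chain carbon bound to two saturated ring carbons and, in words, methyl in place of hydrogen on a saturated chain carbon bound to two saturated ring carbons. Among the measured compounds shown here, the one measured step, a number 3.40 log units higher from compound 1 to compound 2 (beyond the scatter) for (oxan-4-yl)methyl in place of piperidin-4-yl on a saturated ring carbon, is large and lies beyond the scatter. For the measured compounds named here, that step exchanges a whole group, however, and no measured step adds a methyl, so it sets no size for this change. A small rise in this assay is expected, far smaller than that step and perhaps not clear of the scatter. The expected change is a number 0.36 log units higher from compound 2 to compound 3 (beyond the scatter) and rests on the structural change alone. For compound 3 the estimate is 4.8 with an expected range from 4.4 to 5.2 on this read-out.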

Compound 3, distribution coefficient: 5.04
Beside the measured number, compound 3's estimate is 0.24 log units below it, within the range that was stated.
By their numbers in this assay, from the lowest: compound 1; then compound 2; then compound 3.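

In this assay, this position now has a measured step for a single added methyl: the change of methyl in place of hydrogen on a saturated chain carbon bound to two saturated ring carbons gives a number 0.60 log units higher from compound 2 to compound 3 (beyond the scatter), modest in size, so even one carbon at this place separates two compounds by more than the scatter. Taken as a single exchange, the whole change of group gives a number 4.00 log units higher from compound 1 to compound 3 (beyond the scatter), a large step, and most of that distance is already present in the exchange to the (oxan-4-yl)methyl group of compound 2, with the methyl adding only a small further part. No measurement at hand gives a reason for the size of either step.

The compounds shown leave open whether an ethyl group or a longer chain on the same saturated chain carbon would extend the rise or level it off. They also leave open whether the methyl step keeps its size in a 1-(piperidin-4-yl)ethyl analogue, where an amine takes the place of the oxane oxygen.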